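Varying the Aryl Group: Expectation for a Fourth Analogue

This account rests on a few compounds, and the source may have more. Where it says the series, first, only, none or still open, it means among the compounds named here.

Three compounds share one core and differ only in the aryl group attached to the ring amine nitrogen. In an assay on CHO cells for displacement of a labelled ligand from adenosine receptor A1 (Homo sapiens), read by scintillation counting, with a stated time of 120 min, tested at 10 uM (a lower number here means less inhibition, a higher number more inhibition at the concentration tested (going by the name of the read-out)), compound 1 `Nc1scc(CN2CCN(c3ccc(Cl)cc3Cl)CC2)c1C(=O)c1ccc(Cl)cc1` gives 0%. Compound 2 `Nc1scc(CN2CCN(c3cccc(Cl)c3Cl)CC2)c1C(=O)c1ccc(Cl)cc1` gives 2% in this assay, and compound 3 `Nc1scc(CN2CCN(c3ccc([N+](=O)[O-])cc3)CC2)c1C(=O)c1ccc(Cl)cc1` gives 1%. Compound 3 has the second highest of the three numbers, yet all three lie within the scatter of one another, so no ranking can be read from them. The steps of a number 2 percentage points higher from compound 1 to compound 2 (within the scatter), a number 1 percentage points higher from compound 1 to compound 3 (within the scatter) and a number 1 percentage points lower from compound 2 to compound 3 (within the scatter) all fall within the scatter: exchanging one aryl substituent for another has not moved the read-out. Compound 4 `Nc1scc(CN2CCN(c3ccc(OC(F)(F)F)cc3)CC2)c1C(=O)c1ccc(Cl)cc1` differs from compound 3 in one place: trifluoromethoxy in place of nitro on an aromatic carbon. Among the compounds with values here, no measured step covers this particular exchange, but the three steps above show that quite different substituents on this ring all gave the same flat result, so the expected step of no change at the digits printed from compound 3 to compound 4 (within the scatter) is none beyond the scatter. Compound 4 is therefore estimated at 1% in this assay, with a range from -8% to 12%.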

Compound 4, a percentage reported as inhibition, at one concentration (the size of the read-out at that concentration, not a potency): 0%
Beside the measured number, compound 4's estimate is 1 percentage points above it, and the stated range covers the measured number.
By their numbers in this assay, from the lowest: compounds 1, 4, 3 and 2 (each within the scatter of the next).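

The exchange at this aromatic carbon puts trifluoromethoxy, with 5 heavy atoms including 3 fluorine, where nitro had 3, and it takes away 1 of the 2 hydrogen-bond acceptors, yet this assay shows a number 1 percentage points lower from compound 3 to compound 4 (within the scatter). Within the data shown here, the flat result therefore extends to a fluorine-bearing substituent, a kind not seen in the earlier compounds, and the comparisons with the dichlorophenyl compounds agree: a number 2 percentage points lower from compound 2 to compound 4 (within the scatter) and no change at the digits printed from compound 1 to compound 4 (within the scatter). No measurement is available that would explain this lack of response.

The compounds shown leave open whether an aryl group carrying an amine or a carboxylic acid, or a longer chain on the ring amine nitrogen in place of the aryl group, would give a reading beyond the scatter. They also leave open whether any change to the rest of the shared core would do so.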